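Chloro for fluoro on a thiophene-fused quinazoline urea series

This account rests on a few compounds, and the source may have more. Where it says the series, first, only, none or still open, it means among the compounds named here.

Measured compounds:
compound 1, `CN(C)CCNc1nc(-c2ccc(NC(=O)Nc3ccccc3F)cc2)nc2ccsc12`, 600 nM
compound 2, `CN(C)CCNc1nc(-c2ccc(NC(=O)Nc3ccccc3Cl)cc2)nc2ccsc12`, 550 nM
compound 3, `CCN(CC)CCNc1nc(-c2ccc(NC(=O)Nc3ccc(F)cc3)cc2)nc2c(Cl)c(Cl)sc12`, 1130 nM

The three measured compounds were tested in a functional assay on MDA-MB-231 cells (Homo sapiens) for cytotoxicity, read by MTT assay, with a stated time of 72 h; on this read-out higher numbers stand for weaker inhibition and lower numbers for stronger inhibition. Compound 1 gives 600 nM, and compound 2 gives 550 nM; the two differ only by chloro in place of fluoro on an aromatic carbon, and the step is a 1.1-fold lower number from compound 1 to compound 2 (0.04 log units; within the scatter). Compound 3, which gives 1130 nM, carries a different core; the difference between the two cores is not broken down here, and its value sits within the scatter of compound 1 and beyond it for compound 2.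

Compound 4 is `CCN(CC)CCNc1nc(-c2ccc(NC(=O)Nc3ccc(Cl)cc3)cc2)nc2c(Cl)c(Cl)sc12`, not yet measured in this assay. It differs from compound 3 by chloro in place of fluoro on an aromatic carbon. This is the same kind of change as that from compound 1 to compound 2, but not the same: in the earlier pair the place is ortho to a large group, whereas here it is para to a large group.

Going by the values given here, the expectation for compound 4 rests on the one measured instance of this kind of change, where the step of a 1.1-fold lower number from compound 1 to compound 2 (0.04 log units; within the scatter) stayed within the scatter. The step from compound 3 to compound 4 is therefore expected to be small, a 1.1-fold lower number from compound 3 to compound 4 (0.05 log units; within the scatter). Among the compounds with values here, compound 4 is estimated at 1000 nM, with a likely range from 500 nM to 2200 nM, since only one earlier example of the change exists and the cores differ.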

Compound 4, half-maximal inhibitory concentration: 750 nM
Compound 4: middle estimate off by 1.3-fold (0.12 log units), on the high side; the measured number falls inside the stated range.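

In this assay, chloro in place of fluoro on an aromatic carbon, read here as 4-fluorophenyl to 4-chlorophenyl with the halogen para to a large group, gives a 1.5-fold lower number from compound 3 to compound 4 (0.18 log units; within the scatter). Set beside the earlier step, the same change reads alike on the two cores, with no difference that stands out from the usual spread of such measurements: the same change on two cores in this assay, a 1.1-fold lower number (0.04 log units; within the scatter) from compound 1 to compound 2 and a 1.5-fold lower number (0.18 log units; within the scatter) from compound 3 to compound 4, 1.4-fold (0.14 log units) apart, within the scatter of two such steps This shows that, in these two pairs, the exchange of fluoro for chloro carried from one core to the other without a step that can be told from scatter, but it does not show a real gain from chloro, and it cannot separate the role of the core from that of the place on the ring, since the two pairs differ in both.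

The compounds shown leave open whether the same closeness would hold in a pair with both halogen places on a single core, or across further cores, as two pairs are too few to make a rule for the series. They also leave open how a bromo, methoxy or trifluoromethyl group at the place para to a large group would compare with chloro and fluoro.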